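The compounds below may be only part of what the source reports. "The series", "measured", "known", "first", "only" and "open" are said of these compounds alone.

In an ADME assay on BJ cells (Homo sapiens) for cytotoxicity, read by luminescence, with a stated time of 72 h (on this read-out lower numbers stand for an effect already at smaller amounts and higher numbers for an effect only at larger amounts of compound), compound 1 (`CCOC(=O)c1c(-c2cccc(-c3ccccc3)c2)[nH]c2cc(OC)c(OC)cc2c1=O`) gives > 21500 nM, which is a limit of the assay and not a number. Compound 2 (`CCOC(=O)c1c(-c2cccc(-c3ccccc3)c2)[nH]c2cc(OC)c(Cl)cc2c1=O`) gives > 21500 nM, also a limit. Both measured compounds therefore stand at the limit of > 21500 nM in this assay, at which 2 of the 2 values shown sit, and compound 2 has no exact value to serve as a baseline.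

Compound 3 (`CCOC(=O)c1c(-c2cccc(-c3ccccc3)c2)[nH]c2cc(OC)c(F)cc2c1=O`) follows from compound 2 by fluoro in place of chloro on an aromatic carbon, ortho to a methoxy group. Among the compounds with values here, the one measured step at this place is a step that the two limits leave unreadable from compound 1 to compound 2, so it offers no size to carry over. No step beyond the usual scatter is expected in this assay, in either direction, and another limit is the likeliest reading. The expected change is a step that the limit leaves unreadable from compound 2 to compound 3. For compound 3 the estimate is 30000 nM, with an expected range from 15000 nM to 60000 nM.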

Compound 3, half-maximal effective concentration: > 21500 nM
Compound 3: a limit, no number; the forecaster's own chance of this, stated with the estimate: 85%; the middle value is on the limit's open side.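

Compound 3 gives > 21500 nM, again a limit and not a number, so no step among compound 1, compound 2 and compound 3 can be read in this assay: the limit of > 21500 nM in this assay, at which 3 of the 3 values shown sit.

The compounds shown leave open what exact value each has, and so whether methoxy, chloro or fluoro at this place makes any difference.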